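Swapping a Ketone for an Oxazole on a Pyrimidinone Core

The source may report more compounds than this note shows. Statements on the series, on what has been measured and on what is new or still open speak of the compounds shown alone.

Of the compounds shown here, three sharing one core have been tested in an assay on membranes from HEK293 cells for displacement of a labelled ligand from adenosine receptor A2b (Homo sapiens), read by scintillation counting, with a stated time of 30 min; a lower number here means a stronger inhibitor, a higher number a weaker inhibitor. Compound 1 `CC1=C(C(=O)OCc2ccccc2)C(c2cccs2)NC(=O)N1` gives 1920 nM. Compound 2 `CC1=C(C(=O)C2CC2)C(c2ccco2)NC(=O)N1` gives 1060 nM, and compound 3 `CC1=C(C(=O)SC(C)C)C(c2ccoc2)NC(=O)N1` gives 637 nM. The numbers for compound 1 and compound 3 both fall within the usual scatter of the number for compound 2, so on this evidence the three cannot be told apart.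

Compound 4 `CC1=C(c2ncc(C)o2)C(c2ccco2)NC(=O)N1` is a single alteration of compound 2: 5-methyl-1,3-oxazol-2-yl in place of cyclopropylcarbonyl on a double-bonded ring carbon. Going by the values given here, no pair among the measured compounds shows this change, so nothing in the data says how large a step it brings or in which direction. Among the compounds with values here, with the three known numbers so close together, the sensible expectation is that compound 4 lands near compound 2, with a step from compound 2 to compound 4 no larger than the scatter, expected as a 1.2-fold lower number from compound 2 to compound 4 (0.07 log units; within the scatter). For compound 4 the estimate in this assay is 900 nM, expected to fall between 300 nM and 2700 nM.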

Compound 4, inhibition constant: 905 nM
Estimate against measurement, compound 4: 1.0-fold (0.00 log units) below, and the stated range covers the measured number.
By their numbers in this assay, from the lowest: compounds 3, 4, 2 and 1 (each within the scatter of the next, the first and the last beyond it).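

In this assay, going by these compounds alone, the replacement of cyclopropylcarbonyl by 5-methyl-1,3-oxazol-2-yl on the double-bonded ring carbon amounts to a 1.2-fold lower number from compound 2 to compound 4 (0.07 log units; within the scatter) and gives the first comparison of compounds that differ in one place only. Within the data shown here, at this position, then, a group with a three-membered ring and a carbonyl can give way to a five-membered aromatic ring with 2 hetero atoms without a step that stands clear of the scatter, something the earlier compounds, which differ in more than one place, could not show. Nothing available here offers an explanation for this result.

As far as these compounds go, it remains open whether other groups at this position, such as an amine, a carboxylic acid or a longer alkyl chain, would stay as close to compound 2. From the compounds shown here alone, it is also open what the methyl group on the 5-methyl-1,3-oxazol-2-yl ring contributes.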